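Extending the ether chain on compound 3

A few compounds are considered here, and "the series" means these few. Any claim that something is new, unique, unknown or untested is made for them only; others in the source may bear on it.

Compound 3 `CCOCNc1n[n+]([O-])c2ccccc2[n+]1[O-]` stands highest of the three compounds measured in a functional assay on PC-3 cells (Homo sapiens) for cytotoxicity, read by MTT assay, with a stated time of 72 h (a lower number here means a stronger inhibitor, a higher number a weaker inhibitor), where compound 3 gives 15900 nM. Compound 1 `COCNc1n[n+]([O-])c2ccccc2[n+]1[O-]` gives 7510 nM in this assay, and compound 2 `[O-][n+]1nc(NCOC2CCCCC2)[n+]([O-])c2ccccc21` gives 3250 nM. The step of a 2.1-fold higher number from compound 1 to compound 3 (0.33 log units; beyond the scatter) shows that lengthening the chain on the oxygen by one carbon raised the number, while a 2.3-fold lower number from compound 1 to compound 2 (0.36 log units; beyond the scatter) and a 4.9-fold higher number from compound 2 to compound 3 (0.69 log units; beyond the scatter) show that a larger group on that oxygen lowered it.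

Compound 4 `CC(C)CCOCNc1n[n+]([O-])c2ccccc2[n+]1[O-]` differs from compound 3 by isopropyl in place of hydrogen on a saturated chain carbon, two bonds along the chain from an oxygen on a saturated carbon. Among the compounds with values here, the isopentyl chain that results is closer in bulk to the cyclohexyl of compound 2 than to the methyl of compound 1, so the steps that bear on it point in opposite directions, with the larger ones favouring a lower number. A modest decrease is therefore expected, a 2.7-fold lower number from compound 3 to compound 4 (0.42 log units; beyond the scatter), not a large one. Compound 4 is estimated at 6000 nM, within a range of 2500 nM to 14000 nM.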

Compound 4, half-maximal inhibitory concentration: 11100 nM
Estimate against measurement, compound 4: 1.9-fold (0.27 log units) below, within the range that was stated.
By their numbers in this assay, from the lowest: compound 2; then compounds 1, 4 and 3 (each within the scatter of the next, the first and the last beyond it).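

In this assay, isopropyl on the saturated chain carbon gives a 1.4-fold lower number from compound 3 to compound 4 (0.16 log units; within the scatter) and so does not separate compound 4 from compound 3, and the comparison with the methyl ether gives a 1.5-fold higher number from compound 1 to compound 4 (0.17 log units; within the scatter) and does not separate it from compound 1 either. Thus the isopentyl chain on this oxygen does not match the cyclohexyl, as a 3.4-fold higher number from compound 2 to compound 4 (0.53 log units; beyond the scatter) shows. Among these four compounds, the added carbons of an open, branched chain therefore did not bring the number down to that of compound 2, the only one with a ring on the oxygen.

The compounds shown leave open whether a cyclopentyl or phenyl ring, or a longer unbranched chain, would give a number like that of compound 2. Nothing available here accounts for the gap between the cyclohexyl and the isopentyl chain.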